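Phenyl for amino on the ring nitrogen of compound 3

The source may report more compounds than this note shows. Statements on the series, on what has been measured and on what is new or still open speak of the compounds shown alone.

This account follows a single change made to compound 3 `Cc1cc(C)n2nc(SCc3nnc(SCc4cc(=O)c5ccccc5o4)n3N)nc2n1` and asks what it should do to cytotoxicity in a functional assay on MDA-MB-435S cells (Homo sapiens) for cytotoxicity, read by MTT assay, with a stated time of 72 h; a higher number here means a weaker inhibitor, a lower number a stronger inhibitor. Compound 3 stands at a limit in this assay, giving > 25000 nM, which is not a number but the edge of what the measurement reports. Compound 1 `Cc1nnc(Sc2c(C)oc3ccccc3c2=O)o1` also sits at a limit in this assay, giving > 50000 nM. Within the data shown here, compound 2 `Cc1cc(C)n2nc(SCc3nnc(SCc4coc5ccccc5c4=O)n3-c3ccccc3)nc2n1`, which carries a phenyl group on the ring nitrogen of its shared five-membered ring, gives 2900 nM in this assay, the only finite value among the three.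

Compound 4 `Cc1cc(C)n2nc(SCc3nnc(SCc4cc(=O)c5ccccc5o4)n3-c3ccccc3)nc2n1` is compound 3 with one substitution: phenyl in place of amino on an aromatic nitrogen. Among the measured compounds shown here, compound 3 offers only a limit, so no measured step anchors this change. The finite value of compound 2 in this assay, 2900 nM, is the nearest guide, though compound 2 also differs from compound 4 elsewhere. Compound 4 is therefore expected to gain potency, with an estimated step of an at least 4.1-fold lower number from compound 3 to compound 4 (0.61 log units; beyond the scatter). For compound 4 the estimate in this assay is 6000 nM, with a range from 1500 nM to 25000 nM.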

Compound 4, half-maximal inhibitory concentration: > 25000 nM
Compound 4 was reported as a limit; the forecaster's own chance of this, stated with the estimate: 25%; at least 4.1-fold (0.61 log units) between middle value and limit.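

With phenyl on the ring nitrogen, compound 4 still gives only a limit in this assay, > 25000 nM, so phenyl at this place does not by itself bring a finite value on this core. Among these compounds, the step between compound 3 and compound 4 cannot be read because both ends are limits: the limit of > 25000 nM in this assay, at which 2 of the 4 values shown sit. The one readable comparison keeps the phenyl and exchanges only the group of 11 heavy atoms on a saturated chain carbon bound to a sulfur, giving an at least 8.6-fold higher number from compound 2 to compound 4 (0.93 log units; beyond the scatter), so within this pair the finite value goes with that group and not with phenyl alone.

On these data alone, it remains open whether amino on the ring nitrogen, paired with the group carried by compound 2, would retain a finite value. As far as these compounds go, it is also open whether a methyl or a benzyl group on the ring nitrogen would move compound 4 off its limit.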